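The source may hold more compounds than are shown below. What is called first, only, known or untested is meant among the compounds shown, and "the series" means these compounds.

Three compounds share one core and were tested for their ability to inhibit liver cancer cells. In a functional assay on HepG2 cells (Homo sapiens) for inhibition, read by MTT assay, with a stated time of 72 h (a lower number here means a stronger inhibitor, a higher number a weaker inhibitor), compound 1 `COc1cc(O)c(CC=C(C)C)c(O)c1C(=O)/C=C/c1ccc([N+](=O)[O-])cc1` gives 12400 nM. Compound 2 `COc1ccc(/C=C/C(=O)c2c(O)cc(O)cc2OC)cc1` gives 18100 nM. Compound 3 `COc1cc(OC)c(C(=O)/C=C/c2ccc(O)cc2)c(OC)c1` gives 37000 nM, the highest number of the three; its gaps to compound 2 and to compound 1 both lie beyond the usual scatter, so compound 3 is the weakest inhibitor of this small set.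

Compound 4 `COc1cc(OC)c(C(=O)/C=C/c2ccc(C)cc2)c(OC)c1` differs from compound 3 in one place: methyl in place of hydroxy on an aromatic carbon. Among the measured compounds shown here, no measured pair shows this exchange, so there is no basis for expecting a large move in either direction. The expected step in this assay is a 1.1-fold higher number from compound 3 to compound 4 (0.03 log units; within the scatter), within the scatter. Compound 4 is estimated at 40000 nM, between 15000 nM and 110000 nM.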

Compound 4, half-maximal inhibitory concentration: 18400 nM
For compound 4 the middle estimate is 2.2-fold (0.34 log units) above the measured one; the measured number falls inside the stated range.
By their numbers in this assay, from the lowest: compounds 1, 2, 4 and 3 (each within the scatter of the next, the first and the last beyond it).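

In this assay the exchange of 4-hydroxyphenyl to 4-methylphenyl gives a 2.0-fold lower number from compound 3 to compound 4 (0.30 log units; within the scatter) at this position on the shared core. The two groups are therefore not separated here, although hydroxy carries one hydrogen-bond donor and one hydrogen-bond acceptor and methyl carries neither. Nothing available explains this result.

From the compounds shown here alone, whether an amine, a carboxylic acid or a longer chain at this position would move the number beyond the scatter remains open. So does whether the same exchange would give a similar step on a differently substituted core.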